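Added chloro on the fluorophenyl amine: compound 4

The compounds below may be only part of what the source reports. "The series", "measured", "known", "first", "only" and "open" are said of these compounds alone.

The three measured compounds share one core and differ only in the aryl amine. In a functional assay on NCI-H1975 cells (Homo sapiens) for inhibition, read by MTT assay, with a stated time of 72 h (a higher number here means a weaker inhibitor, a lower number a stronger inhibitor), compound 1 `C=CC(=O)Nc1cccc(NC(=O)CSc2nc(Nc3ccccc3F)c3ccccc3n2)c1` gives 6580 nM. Compound 2 `C=CC(=O)Nc1cccc(NC(=O)CSc2nc(Nc3ccccc3Cl)c3ccccc3n2)c1` gives 10000 nM. Compound 3 `C=CC(=O)Nc1cccc(NC(=O)CSc2nc(Nc3ccc(F)cc3)c3ccccc3n2)c1` gives 4430 nM. Compound 3 carries the lowest of the three numbers, but its gap to compound 1 is within the scatter and only its gap to compound 2 is beyond it, so compounds 1 and 3 cannot be ordered against each other.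

Compound 4 `C=CC(=O)Nc1cccc(NC(=O)CSc2nc(Nc3ccc(F)c(Cl)c3)c3ccccc3n2)c1` is compound 3 with chloro in place of hydrogen on an aromatic carbon. The measured step nearest to this change is the halogen swap, a 1.5-fold higher number from compound 1 to compound 2 (0.18 log units; within the scatter); the changes of aryl pattern, a 1.5-fold lower number from compound 1 to compound 3 (0.17 log units; within the scatter) and a 2.3-fold lower number from compound 2 to compound 3 (0.35 log units; beyond the scatter), were likewise small to modest. For the measured compounds named here, no measured step adds a second halogen to the same ring, so the expectation rests on the halogen swap alone. Compound 4 is therefore expected to show only a small step, a 1.0-fold higher number from compound 3 to compound 4 (0.01 log units; within the scatter), with no clear direction. The estimate for compound 4 is 4500 nM, within 2000 nM to 10000 nM.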

Compound 4, half-maximal inhibitory concentration: > 50000 nM
Compound 4 was reported as a limit (the forecaster's own chance of this, stated with the estimate: 15%); middle value at least 11-fold (1.04 log units) from the limit.
By their numbers in this assay, from the lowest: compounds 3, 1 and 2 (each within the scatter of the next, the first and the last beyond it). At a limit, above all of these: compound 4.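

Compound 4 is reported only as a limit, not as a number, in this assay: the limit of > 50000 nM in this assay, at which 1 of the 4 values shown sits. Chloro ortho to a fluoro group gives the first large step in the series, an at least 11-fold higher number from compound 3 to compound 4 (1.05 log units; beyond the scatter), whereas the earlier changes of halogen and aryl pattern were within the scatter or modest. The 3-chloro-4-fluorophenyl amine also separates from both 2-halophenyl amines, an at least 5.0-fold higher number from compound 2 to compound 4 (0.69 log units; beyond the scatter) and an at least 7.5-fold higher number from compound 1 to compound 4 (0.88 log units; beyond the scatter), so this position on the ring does not tolerate the change in the way the earlier aryl variations did.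

Still open, from the compounds shown here alone, is whether the step follows from chloro at this place alone or from its pairing with the fluoro group. A 3-chlorophenyl, 3-methylphenyl or 3-methoxyphenyl amine on the shared core would separate these readings.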